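Adding a Chloro to Compound 2

The compounds below may be only part of what the source reports. "The series", "measured", "known", "first", "only" and "open" are said of these compounds alone.

In a functional assay on A549 cells (Homo sapiens) for antiproliferative activity, read by MTT assay, with a stated time of 48 h (a lower number here means a stronger inhibitor, a higher number a weaker inhibitor), compound 1 `O=C(/C=C\Nc1ccc(C(F)(F)F)cc1)c1cn(-c2ccccc2)nc1-c1ccccc1` gives > 50000 nM as a limit of the test and not a number. Within the data shown here, compound 2 `O=C(/C=C\Nc1ccc(O)cc1)c1cn(-c2ccccc2)nc1-c1ccccc1` gives 3210 nM and so holds the only true number so far. Among the measured compounds shown here, the one measured step is an at least 15-fold lower number from compound 1 to compound 2 (1.19 log units; beyond the scatter) and it is large. That step starts from compound 1 with the limit of > 50000 nM in this assay, at which 1 of the 2 values shown sits, as a limit and not a number.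

Compound 3 `O=C(/C=C\Nc1ccc(O)cc1)c1cn(-c2ccccc2)nc1-c1ccc(Cl)cc1` keeps the hydroxy of compound 2 and adds a different change, chloro in place of hydrogen on an aromatic carbon in which phenyl becomes 4-chlorophenyl. For the measured compounds named here, the measured step swapped another group at another place, so it offers little guide here, and no measurement yet covers chloro in place of hydrogen. The expectation therefore stays anchored on compound 2 at 3210 nM as the starting point. The expected change is a 1.3-fold lower number from compound 2 to compound 3 (0.11 log units; within the scatter) and it is estimated to stay within the scatter, with no firm direction. For compound 3 the estimate is 2500 nM with an expected range of 800 nM to 9000 nM around it.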

Compound 3, half-maximal inhibitory concentration: 1910 nM
Beside the measured number, compound 3's estimate is 1.3-fold (0.12 log units) above it, within the range that was stated.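

In this assay, a chloro on an aromatic carbon para to a large group gives a 1.7-fold lower number from compound 2 to compound 3 (0.23 log units; within the scatter), so phenyl and 4-chlorophenyl cannot be told apart by this read-out. Among these compounds, this is the first measured change at this position, and it shows that a single chlorine atom can be placed here with no shift beyond the scatter. Among the compounds shown here, the only earlier step, an at least 15-fold lower number from compound 1 to compound 2 (1.19 log units; beyond the scatter), was made at another place and was large, so the two places have so far answered very differently, though each rests on one change alone. Compound 1 remains the one compound that sits at a limit and not at a number: the limit of > 50000 nM in this assay, at which 1 of the 3 values shown sits.

One small group says little about how much room for change this position has, and an amine, a carboxylic acid or a longer chain such as butoxy in place of the chloro could still move the number well beyond the scatter. On these data alone, it also remains open whether the chloro would act the same way on a compound carrying a group other than the hydroxy.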